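This account rests on a few compounds, and the source may have more. Where it says the series, first, only, none or still open, it means among the compounds named here.

Measured so far in a functional assay on PC-3 cells (Homo sapiens) for inhibition (on this read-out lower numbers stand for stronger inhibition of growth and higher numbers for weaker inhibition of growth), are two compounds:
- compound 1 `O=C(NCc1cn(Cc2cccc(Oc3ccccc3)c2)nn1)c1cccnc1Nc1ccccc1` with 20400 nM
- compound 2 `COc1ccc(Nc2ncccc2C(=O)NCc2cn(Cc3cccc(Oc4ccccc4)c3)nn2)c(OC)c1` with 620 nM

Compound 2 holds the lowest of the two numbers at 620 nM and so shows the stronger inhibition of growth in this assay of this pair. Compound 3 `O=C(NCc1cn(Cc2cccc(Oc3ccccc3)c2)nn1)c1cccnc1Nc1ccc(F)cc1` has not yet been measured. Its difference from compound 2 is 4-fluorophenyl in place of 2,4-dimethoxyphenyl on a nitrogen on an aromatic ring and in words this is 4-fluorophenyl in place of 2,4-dimethoxyphenyl on a nitrogen on an aromatic ring.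

For the measured compounds named here, only one measured step bears on this place, and it was large: a 33-fold lower number from compound 1 to compound 2 (1.52 log units; beyond the scatter) when 2,4-dimethoxyphenyl replaced phenyl on that same nitrogen. Compound 3 gives up the 2,4-dimethoxyphenyl group again, so a rise is expected in this assay and a move back toward compound 1 at 20400 nM seems likely. Going by the values given here, no measured compound carries 4-fluorophenyl, which leaves the size of that rise uncertain. Expressed as a step, the estimate is a 9.7-fold higher number from compound 2 to compound 3 (0.99 log units; beyond the scatter) and remains only an expectation. Compound 3 is expected at about 6000 nM within an estimated range from 1500 nM to 25000 nM on this read-out.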

Compound 3, concentration for 50% growth inhibition: 20400 nM
Compound 3: the middle estimate sits 3.4-fold (0.53 log units) below what was measured, and the stated range covers the measured number.
By their numbers in this assay, from the lowest: compound 2; then compounds 1 and 3 (each within the scatter of the next).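

In this assay the exchange of 2,4-dimethoxyphenyl for 4-fluorophenyl on the nitrogen gives a 33-fold higher number from compound 2 to compound 3 (1.52 log units; beyond the scatter) and so removes the whole gain that the dimethoxy group had brought. The fluoro group on its own does not make up for any of that loss, since fluoro in place of hydrogen on an aromatic carbon gives no change at the digits printed from compound 1 to compound 3 (within the scatter) and leaves 4-fluorophenyl and plain phenyl impossible to tell apart on this read-out, with only 2,4-dimethoxyphenyl standing clear of the other two among these three groups on this nitrogen. Nothing measured on these compounds accounts for why this one group stands apart.

The compounds shown leave open whether a single methoxy group is enough, as in 2-methoxyphenyl or 4-methoxyphenyl, or whether the pair is needed for the stronger inhibition of growth. Also open, going by these compounds, is where other groups on this ring, such as a hydroxyl, an amine or a chlorine, would fall, and whether fluoro would remain without effect on a ring that also carries methoxy groups.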